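Aryl substituent changes on a shared core

The compounds below may be only part of what the source reports. "The series", "measured", "known", "first", "only" and "open" are said of these compounds alone.

Measured compounds in a functional assay on HepG2 cells (Homo sapiens) for inhibition, read by MTT assay, with a stated time of 24 h; on this read-out higher numbers stand for weaker inhibition and lower numbers for stronger inhibition:
compound 1 `CC1(C)[C@H]2CC[C@]1(C)N(Cc1cn(-c3ccccc3Br)nn1)C(=O)C2` — 150 nM
compound 2 `CC1(C)[C@H]2CC[C@]1(C)N(Cc1cn(-c3ccccc3C#N)nn1)C(=O)C2` — 180 nM
compound 3 `COc1ccccc1-n1cc(CN2C(=O)C[C@@H]3CC[C@@]2(C)C3(C)C)nn1` — 110 nM

Compound 1 stands second highest of the three numbers. Its nearest neighbour is compound 2, with a 1.2-fold higher number from compound 1 to compound 2 (0.08 log units; within the scatter); its furthest is compound 3, with a 1.4-fold lower number from compound 1 to compound 3 (0.13 log units; within the scatter). The remaining pair gives a 1.6-fold lower number from compound 2 to compound 3 (0.21 log units; within the scatter). All three steps lie within the scatter, so none of the three compounds can be ordered against another on these numbers.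

Compound 4 `Cc1cccc(-n2cc(CN3C(=O)C[C@@H]4CC[C@@]3(C)C4(C)C)nn2)c1` is the next case. It differs from compound 1 by 3-methylphenyl in place of 2-bromophenyl on an aromatic nitrogen. Among the compounds with values here, none of the measured steps matches this change: each of them exchanges one group for another on an aromatic carbon, and none brings in methyl or moves the group to a different place on the ring. Within the data shown here, the only guides are the three measured steps, and each of them stayed within the scatter when the group on the phenyl ring was exchanged. On that basis the step from compound 1 to compound 4 is expected to be small, a 1.1-fold higher number from compound 1 to compound 4 (0.03 log units; within the scatter), with no direction favoured beyond the scatter. Compound 4 is therefore estimated at 160 nM, within 70 nM to 360 nM.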

Compound 4, half-maximal inhibitory concentration: 300 nM
The estimate for compound 4 lay 1.9-fold (0.27 log units) below the measured number; the range from low to high includes it.
By their numbers in this assay, from the lowest: compounds 3, 1, 2 and 4 (each within the scatter of the next, the first and the last beyond it).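

Within the data shown here, with 3-methylphenyl on the aromatic nitrogen, this assay gives the first step in this set that lies beyond the scatter, a 2.7-fold higher number from compound 3 to compound 4 (0.44 log units; beyond the scatter), so the aryl group at this position can shift the number measurably, whereas exchanges among the 2-substituted phenyl groups did not. The other two steps, a 2.0-fold higher number from compound 1 to compound 4 (0.30 log units; within the scatter) and a 1.7-fold higher number from compound 2 to compound 4 (0.22 log units; within the scatter), remain within the scatter, so compound 4 separates only from compound 3 and cannot be ordered against compound 1 or compound 2. No measured property of these aryl groups is available to account for the separation from compound 3.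

Because 3-methylphenyl differs from 2-methoxyphenyl in both the group and its place on the phenyl ring, the compounds shown cannot assign the step from compound 3 to either change, and a pairing of 2-methylphenyl with 3-methylphenyl or of 2-methoxyphenyl with 3-methoxyphenyl would separate the two. Also open, on these data alone, is how an amine or a carboxylic acid on the phenyl ring would read in this assay on the shared core.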